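Series notes: from compound 2 to compound 4

A few compounds are considered here, and "the series" means these few. Any claim that something is new, unique, unknown or untested is made for them only; others in the source may bear on it.

The compounds share one core. Compound 2 is `CS(=O)(=O)c1ccc(-c2cnc3[nH]cc(-c4nnc(-c5ccc(F)cc5)o4)c(=O)c3c2)cc1`. In a functional assay on A549 cells (Homo sapiens) for inhibition, read by MTT assay, with a stated time of 24 h, tested at 5 uM (a higher number here means more inhibition of growth at the concentration tested, a lower number less inhibition of growth), compound 2 gives 3.11%, the lowest of the three numbers in hand, though within the scatter of both others. Compound 1, `CS(=O)(=O)c1ccc(-c2cnc3[nH]cc(-c4nnc(-c5ccncc5)o4)c(=O)c3c2)cc1`, gives 6.76% in this assay, and compound 3, `N#Cc1ccc(-c2cnc3[nH]cc(-c4nnc(-c5ccc(Cl)cc5)o4)c(=O)c3c2)cc1`, gives 7.6%; neither gap to compound 2 exceeds the scatter, so no order among the three can be read. Among the measured compounds shown here, the single measured step at the same position is a number 3.7 percentage points lower from compound 1 to compound 2 (within the scatter), itself within the scatter. Compound 4 is `Cc1cccc(-c2nnc(-c3c[nH]c4ncc(-c5ccc(S(C)(=O)=O)cc5)cc4c3=O)o2)c1`; it differs from compound 2 by 3-methylphenyl in place of 4-fluorophenyl on an aromatic carbon. For the measured compounds named here, only the step from compound 1 to compound 2 bears on this change, and it was small; compound 3 differs from compound 2 in more than one place and offers no single-change comparison. Hence no step beyond the scatter is expected: the estimated change is a number 0.9 percentage points higher from compound 2 to compound 4 (within the scatter). Compound 4 is expected to give 4%, with a range from -4% to 12%.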

Compound 4, percent growth inhibition at one concentration: 7.92%
Beside the measured number, compound 4's estimate is 3.9 percentage points below it; the range from low to high includes it.
By their numbers in this assay, from the lowest: compounds 2, 1, 3 and 4 (each within the scatter of the next).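

Two further steps now stand at this position in this assay and both are small: 3-methylphenyl in place of 4-fluorophenyl gives a number 4.8 percentage points higher from compound 2 to compound 4 (within the scatter) and 3-methylphenyl in place of pyridin-4-yl gives a number 1.2 percentage points higher from compound 1 to compound 4 (within the scatter) on the same aromatic carbon. With the earlier step between compound 1 and compound 2, all three groups at this position are now joined by single-change steps, and none of these steps separates one group from another. Nothing available on these compounds speaks to the reason for these numbers.

Still open, from the compounds shown here alone, is whether any group at this position gives a step beyond the scatter, since all three groups here are six-membered aromatic rings. An amine, a carboxylic acid or a longer alkyl chain on this carbon would test that.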